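This account rests on a few compounds, and the source may have more. Where it says the series, first, only, none or still open, it means among the compounds named here.

Compound 1 `O=C(Nc1nnc(-c2ccc(Cl)cc2)s1)c1ccccc1F` gives 724 nM in a functional assay on the whole organism (integument) for inhibition, with Chilo suppressalis as the target, read by scintillation counting, with a stated time of 72 h; on this read-out lower numbers stand for stronger inhibition and higher numbers for weaker inhibition. Compound 2 `O=C(Nc1nnc(-c2ccc(Cl)cc2)s1)c1ccccc1Cl` reaches only the limit > 5010 nM in this assay. Compound 3 `O=C(Nc1nnc(-c2ccc(Cl)cc2)s1)c1ccccc1Br` likewise reaches only the limit > 5010 nM in this assay, so compound 3 stands at the limit of > 5010 nM in this assay, at which 2 of the 3 values shown sit, with no number of its own. Compound 4 `O=C(Nc1nnc(-c2ccc(Cl)cc2)s1)c1ccccc1I` differs from compound 3 by iodo in place of bromo on an aromatic carbon. The steps measured so far both start at fluoro: an at least 6.9-fold higher number from compound 1 to compound 2 (0.84 log units; beyond the scatter) and an at least 6.9-fold higher number from compound 1 to compound 3 (0.84 log units; beyond the scatter), while a step that the two limits leave unreadable from compound 2 to compound 3. Chloro and bromo both sit at the limit, so the further step from bromo to iodo is expected to stay at or near that limit: a step that the limit leaves unreadable from compound 3 to compound 4. For compound 4 the estimate is 8000 nM, with a range from 3000 nM to 30000 nM, most likely reported again only as a limit.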

Compound 4, half-maximal inhibitory concentration: > 5010 nM
Compound 4: no number, only a limit (the forecaster's own chance of this, stated with the estimate: 85%); the middle value is on the limit's open side.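

In this assay, iodo on this aromatic carbon, ortho to a large group, falls on the same side as chloro and bromo: an at least 6.9-fold higher number from compound 1 to compound 4 (0.84 log units; beyond the scatter). The steps from compound 2 and from compound 3 to compound 4 cannot be read, so chloro, bromo and iodo cannot be put in any order. Among these four halogens, only fluoro gives a number rather than a limit, and the limit now covers most of the set: the limit of > 5010 nM in this assay, at which 3 of the 4 values shown sit.

Still open, as far as these compounds go, is how far beyond the limit compound 2, compound 3 and compound 4 lie. Also open, from the compounds shown here alone, is whether a methyl, a methoxy or an amine at this place would give a number.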